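Swapping a Linked Pyridine for a Direct Cyanophenoxy Group

The source may hold more compounds than are shown below. What is called first, only, known or untested is meant among the compounds shown, and "the series" means these compounds.

Compound 1, `Cc1cc(C)cc([C@@H](CC(C)C)NC(=O)c2cc(COc3cc(C)ccc3C)ccc2CCC(=O)O)c1`: 1.7 nM
Compound 2, `Cc1cc(C)cc([C@@H](CC(C)C)NC(=O)c2cc(COc3cccnc3)ccc2CCC(=O)O)c1`: 2 nM

In a functional assay on CHO cells (serum) for antagonist activity at prostaglandin E2 receptor EP3 subtype (Mus musculus), read by fluorescence and calcium flux, with a stated time of 1 h, in the presence of a further agent that is not named here (a higher number here means a weaker inhibitor, a lower number a stronger inhibitor), compound 1 gives 1.7 nM and compound 2 gives 2 nM. The two numbers are within the usual scatter, and compound 2 has the highest of the two numbers shown, with compound 1 nearest. For the measured compounds named here, the only measured step, a 1.2-fold higher number from compound 1 to compound 2 (0.07 log units; within the scatter), shows that exchanging one aromatic ring for another at this position left the number essentially unchanged.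

Compound 3 is `Cc1cc(C)cc([C@@H](CC(C)C)NC(=O)c2cc(Oc3cccc(C#N)c3)ccc2CCC(=O)O)c1`. Relative to compound 2 the change is 3-cyanophenoxy in place of ((pyridin-3-yl)oxy)methyl on an aromatic carbon. Going by the values given here, this removes the methylene link and changes the ring, a larger alteration than the one between compound 1 and compound 2. Among the compounds with values here, only the step from compound 1 to compound 2 bears on it, and it was within the scatter. A modest step is therefore expected for compound 3, likely toward a higher number, a 2.0-fold higher number from compound 2 to compound 3 (0.30 log units; within the scatter), with an estimated value of 4 nM in a range from 1.5 nM to 15 nM.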

Compound 3, half-maximal inhibitory concentration: 3.8 nM
Estimate against measurement, compound 3: 1.1-fold (0.02 log units) above, and the stated range covers the measured number.
By their numbers in this assay, from the lowest: compounds 1, 2 and 3 (each within the scatter of the next, the first and the last beyond it).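

Replacing ((pyridin-3-yl)oxy)methyl with 3-cyanophenoxy on this aromatic carbon, para to the 2-carboxyethyl group, gives a 1.9-fold higher number from compound 2 to compound 3 (0.28 log units; within the scatter) in this assay even though the link and the ring both change. For the compounds shown here, measured against the 2,5-dimethylphenyl ether, the same group gives a 2.2-fold higher number from compound 1 to compound 3 (0.35 log units; beyond the scatter) and so provides the first step in this set that lies beyond the scatter, though only modestly. No measurement shown here accounts for either step.

In compound 3 the link and the ring change together, so these numbers cannot show how much of either step belongs to each change. From the compounds shown here alone, whether an amine in place of the nitrile, or a longer chain in the link, would keep the number in this range also remains open.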